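Bromo substitution on the aryl ring of compound 2

The compounds below may be only part of what the source reports. "The series", "measured", "known", "first", "only" and "open" are said of these compounds alone.

Compound 1 `Cn1nnnc1SCC(=O)N/N=c1/scc(-c2ccccc2)n1-c1ccccc1` gives 80.7% in a functional assay on C6 cells (Rattus norvegicus) for cytotoxicity, read by MTT assay, with a stated time of 24 h, tested at 12 ug/mL; a lower number here means a stronger effect, a higher number a weaker effect of the compound at the concentration tested. Compound 2 `O=C(CSc1nnnn1-c1ccccc1)N/N=c1/scc(-c2ccccc2)n1-c1ccccc1` gives 47.1%, and compound 3 `Cc1nnc(SCC(=O)N/N=c2/scc(-c3ccc(Cl)cc3)n2-c2ccccc2)s1` gives 76.6%. One single-point step connects the set: a number 33.6 percentage points lower from compound 1 to compound 2 (beyond the scatter). Compound 2 therefore has the lowest number of the three; compound 3 lies nearest, with a number higher by beyond the scatter, and compound 1 furthest.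

Compound 4 `O=C(CSc1nnnn1-c1ccccc1)N/N=c1/scc(-c2ccc(Br)cc2)n1-c1ccccc1` differs from compound 2 in one place: bromo in place of hydrogen on an aromatic carbon. Within the data shown here, no measured step of this kind exists. Among the measured compounds shown here, the only related comparison is between compound 1 and compound 3, which carry different groups on both the side chain and this ring, so only their two values can be set side by side: compound 1 gives 80.7% and compound 3 gives 76.6%, a difference within the scatter. On that slender basis the expected step of a number 2.9 percentage points higher from compound 2 to compound 4 (within the scatter) is none beyond the scatter. Compound 4 is accordingly estimated at 50%, within 30% to 72%.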

Compound 4, a percentage reported as activity, at one concentration (the size of the read-out at that concentration, not a potency): 58.6%
Compound 4: the middle estimate sits 8.6 percentage points below what was measured; the range from low to high includes it.
By their numbers in this assay, from the lowest: compound 2; then compound 4; then compounds 3 and 1 (each within the scatter of the next).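

In this assay, among these compounds, the change from phenyl to 4-bromophenyl gives the first readable step on this ring: a number 11.5 percentage points higher from compound 2 to compound 4 (beyond the scatter). A higher number here means a weaker effect at the concentration tested, so in this pair bromo on the aromatic carbon weakens the effect, and the position is shown to respond to substitution; the step is modest beside the large one on the aromatic nitrogen, a number 33.6 percentage points lower from compound 1 to compound 2 (beyond the scatter). No measurement shown accounts for the direction or size of the bromo step.

Still open, going by these compounds, is whether an amine or a carboxylic acid on the same ring carbon would move the number up or down. Also open, on these data alone, is whether the bromo step would recur with methyl rather than phenyl on the aromatic nitrogen.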